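A few compounds are considered here, and "the series" means these few. Any claim that something is new, unique, unknown or untested is made for them only; others in the source may bear on it.

In an ADME assay on the whole organism (plasma, Macaca fascicularis) for protein binding, read by LC-MS, using equilibrium dialysis and cassette dosing, with a stated time of 24 h, at a dose of 1 mg/kg by the oral route (on this read-out lower numbers stand for a smaller free fraction and higher numbers for a larger free fraction), compound 1 `CCCCN(c1nc2c(C(=O)NC)cccc2o1)[C@H](C)c1ccc(-c2ccccc2-c2nnn[nH]2)cc1` gives 0.000975, the second highest of the three numbers measured here. Compound 2 `CCCCN(c1nc2c(-c3nccn3C)cccc2o1)[C@H](C)c1ccc(-c2ccccc2-c2nnn[nH]2)cc1` gives 0.00299, and compound 3 `C[C@H](c1ccc(-c2ccccc2-c2nc(=O)o[nH]2)cc1)N(CC1CC1)c1nc2c(C(=O)O)cccc2o1` gives 0.0000851, the lowest of the three. For the measured compounds named here, the only step that changes a single place in the shared core is a 3.1-fold higher number from compound 1 to compound 2 (0.49 log units; beyond the scatter), in which an aromatic ring took the place of the amide group. Compound 4 `CCCCN(c1nc2c(-c3ccccn3)cccc2o1)[C@H](C)c1ccc(-c2ccccc2-c2nnn[nH]2)cc1` differs from compound 1 in a closely related way: pyridin-2-yl in place of methylcarbamoyl on an aromatic carbon. Because a 3.1-fold higher number from compound 1 to compound 2 (0.49 log units; beyond the scatter) followed the same kind of exchange, a modest rise in unbound fraction beyond the scatter is expected for compound 4, of about a 2.3-fold higher number from compound 1 to compound 4 (0.35 log units; beyond the scatter). Compound 4 is therefore estimated at 0.0022, with a range from 0.0009 to 0.0055.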

Compound 4, unbound fraction: 0.00129
For compound 4 the middle estimate is 1.7-fold (0.23 log units) above the measured one; low and high end bracket the measured number.
By their numbers in this assay, from the lowest: compound 3; then compounds 1 and 4 (each within the scatter of the next); then compound 2.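

At this aromatic carbon, pyridin-2-yl in place of methylcarbamoyl gives a 1.3-fold higher number from compound 1 to compound 4 (0.12 log units; within the scatter) in this assay, so swapping the amide group for an aromatic ring does not by itself shift the unbound fraction. The choice of ring does count, with a 2.3-fold lower number from compound 2 to compound 4 (0.37 log units; beyond the scatter) when pyridin-2-yl replaces 1-methyl-1H-imidazol-2-yl. Nothing available explains the gap between these two rings. Going by these compounds, what a dimethylamino group or a morpholine ring would do on this same carbon remains open.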